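The source may hold more compounds than are shown below. What is called first, only, known or untested is meant among the compounds shown, and "the series" means these compounds.

Compound 3 `CCCCCc1c(C(C)C)nc(C(C)C)c(CO)c1-c1ccccc1CO` gives 44% in an assay on CHO cells for inhibition of Glucagon receptor (Homo sapiens), tested at 20 uM (on this read-out lower numbers stand for less inhibition and higher numbers for more inhibition at the one concentration tested (going by the name of the read-out)), the lowest of the three numbers measured, though within the scatter of both neighbours: compound 2 `CCCCCc1c(C(C)C)nc(C(C)C)c(CO)c1-c1cccc(C)c1` gives 46% and compound 1 `CCCCCc1c(C(C)C)nc(C(C)C)c(CO)c1-c1cccc(Cl)c1` gives 49%. Compound 4 `CCCCCc1c(C(C)C)nc(C(C)C)c(CO)c1-c1ccc(C(C)C)cc1` has not yet been measured. Its change from compound 3 is 4-isopropylphenyl in place of 2-(hydroxymethyl)phenyl on an aromatic carbon. The two steps that bear on this both end at compound 3: a number 5 percentage points lower from compound 1 to compound 3 (within the scatter) and a number 2 percentage points lower from compound 2 to compound 3 (within the scatter). Both swaps of the aryl group on that carbon stayed within the scatter, so another swap at the same place is expected to move the number little in either direction. Compound 4 is therefore expected to give about 47%, between 33% and 61%, a step of a number 3 percentage points higher from compound 3 to compound 4 (within the scatter).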

Compound 4, a percentage reported as inhibition, at one concentration (the size of the read-out at that concentration, not a potency): 34%
Beside the measured number, compound 4's estimate is 13 percentage points above it, within the range that was stated.
By their numbers in this assay, from the lowest: compounds 4, 3, 2 and 1 (each within the scatter of the next, the first and the last beyond it).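

In this assay, among the compounds shown here, the aryl group on this carbon, opposite the ring nitrogen, does affect the number: a number 12 percentage points lower from compound 2 to compound 4 (beyond the scatter) and a number 15 percentage points lower from compound 1 to compound 4 (beyond the scatter) are the first steps at this position beyond the scatter, while a number 10 percentage points lower from compound 3 to compound 4 (within the scatter) remains within it. So the 4-isopropylphenyl group separates from the 3-chlorophenyl and 3-methylphenyl groups but not from 2-(hydroxymethyl)phenyl. Nothing available explains this difference.

The compounds shown leave open whether the isopropyl group itself or its place on the phenyl ring matters. They also leave open what an amine or a carboxylic acid on that phenyl ring would do.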